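This account rests on a few compounds, and the source may have more. Where it says the series, first, only, none or still open, it means among the compounds named here.

Measured so far:
Compound 1, `COc1cccc(/C=C2/C(C)=C(CC(=O)O)c3cc(F)ccc32)c1` — 520000 nM in a functional assay on NIH3T3 cells (Mus musculus) for antiproliferative activity; a lower number here means a stronger inhibitor, a higher number a weaker inhibitor
Compound 2, `COc1ccccc1/C=C1/C(C)=C(CC(=O)O)c2cc(F)ccc21` — 500000 nM
Compound 3, `CC1=C(CC(=O)O)c2cc(F)ccc2/C1=C\c1ccc(C)o1` — 100000 nM; 60000 nM (2 entries)

Compound 2 holds the lowest of the two single numbers, but its nearest neighbour, compound 1, sits within the scatter of it, so the two cannot be ranked. Compound 3 has no single number; its several entries, (the several entries of compound 3 in this assay, 100000 nM; 60000 nM (2 entries)), all lie well under the values of compound 1 and compound 2.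

The change now considered is furan-3-yl in place of 2-methoxyphenyl on a double-bonded chain carbon bound to a double-bonded ring carbon, giving compound 4, `CC1=C(CC(=O)O)c2cc(F)ccc2/C1=C\c1ccoc1`. Going by the values given here, only one measured step exists, a 1.0-fold lower number from compound 1 to compound 2 (0.02 log units; within the scatter), and it concerns a shift of the methoxy group on the same six-membered ring, so it says little about replacing that ring by a five-membered one. The values of compound 3, which also carries a five-membered ring with one hetero atom at this place, are the closest guide.

Compound 4 is therefore expected to give a lower number than compound 2, a step of about a 3.3-fold lower number from compound 2 to compound 4 (0.52 log units; beyond the scatter), with an estimate of 150000 nM and a range from 40000 nM to 600000 nM.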

Compound 4, half-maximal inhibitory concentration: 170000 nM
Estimate against measurement, compound 4: 1.1-fold (0.05 log units) below; the range from low to high includes it.
By their numbers in this assay, from the lowest: compound 4; then compounds 2 and 1 (each within the scatter of the next).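

In this assay, this place on a double-bonded chain carbon bound to a double-bonded ring carbon now responds beyond the scatter, which moving the methoxy group between compound 1 and compound 2 did not show. Furan-3-yl gives a 2.9-fold lower number from compound 2 to compound 4 (0.47 log units; beyond the scatter), and against the other methoxyphenyl isomer it gives a 3.1-fold lower number from compound 1 to compound 4 (0.49 log units; beyond the scatter), so the lower number holds for both pairs, though both steps are modest. No step to compound 3 can be read, as its entries give no single number: the several entries of compound 3 in this assay, 100000 nM; 60000 nM (2 entries)

The compounds shown leave open whether the lower number comes with the five-membered ring itself or simply with the loss of the methoxyphenyl group. A plain phenyl group and a thiophen-3-yl group at this place would separate these two readings.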